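This account rests on a few compounds, and the source may have more. Where it says the series, first, only, none or still open, it means among the compounds named here.

Compound 2 `COc1cccc(N2CCN(C(=O)c3oc(C)nc3-c3ccccc3)CC2)c1` is the reference point here. In a functional assay on HL-60 cells (Homo sapiens) for inhibition, read by MTT assay, with a stated time of 72 h (on this read-out higher numbers stand for weaker inhibition and lower numbers for stronger inhibition), compound 2 gives 34.8 nM, the lowest of the two numbers recorded, and its closest neighbour is compound 1 `COc1cccc(N2CCN(C(=O)c3oc(C)nc3-c3ccccc3F)CC2)c1`, which in this assay gives 56.1 nM; the step of a 1.6-fold lower number from compound 1 to compound 2 (0.21 log units; within the scatter) keeps the two within the scatter. Compound 3 `COc1cccc(N2CCN(C(=O)c3oc(C)nc3-c3cccc(F)c3)CC2)c1` in this assay gives "not active" (no number reported), reported without a number. The next compound, compound 4 `Cc1nc(-c2ccccc2)c(C(=O)N2CCN(c3cccc(C#N)c3)CC2)o1`, differs from compound 2 in a single place: cyano in place of methoxy on an aromatic carbon. For the measured compounds named here, no measured step addresses this change: the only step in hand, from compound 1 to compound 2, concerns fluoro on a different ring, and compound 3 likewise differs from compound 2 on that other ring rather than at the methoxy. The expectation for compound 4 therefore rests on compound 2 alone, with a wide range; the estimated step of a 1.7-fold higher number from compound 2 to compound 4 (0.24 log units; within the scatter) is expected to stay within the scatter. For compound 4 the estimated value is 60 nM, between 18 nM and 250 nM.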

Compound 4, half-maximal inhibitory concentration: 39.6 nM
Estimate against measurement, compound 4: 1.5-fold (0.18 log units) above; low and high end bracket the measured number.
By their numbers in this assay, from the lowest: compounds 2, 4 and 1 (each within the scatter of the next).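

In this assay, replacing methoxy with cyano gives a 1.1-fold higher number from compound 2 to compound 4 (0.06 log units; within the scatter), so at this place, meta to a large group, the two groups cannot be told apart. For the compounds shown here, the earlier comparisons varied only fluoro on the other ring, so this is the first reading of any change at this position, and it shows that the methoxy is not uniquely required there for a value in this range. Nothing given here bears on why the two groups read alike.

From the compounds shown here alone, whether this place also accepts an amine, a carboxylic acid or a longer chain remains open. So does whether cyano would read the same at another place on this ring, or alongside the fluoro groups of compound 1 and compound 3.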